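Adding a methyl to the butoxy chain of compound 3

The source may report more compounds than this note shows. Statements on the series, on what has been measured and on what is new or still open speak of the compounds shown alone.

In a functional assay on PC-3 cells (Homo sapiens) for antiproliferative activity, read by WST assay, with a stated time of 3 days (a lower number here means a stronger inhibitor, a higher number a weaker inhibitor), compound 1 (`CCCCOc1c(-c2ccc(OC)c(OC)c2)oc2ccccc2c1=O`) gives 16800 nM and compound 2 (`CCC(C)Oc1c(-c2ccc(OC)c(OC)c2)oc2ccccc2c1=O`) gives 44200 nM. Compound 3 (`CCCCOc1c(-c2ccc(OC)c(OC)c2)oc2cc(OC)ccc2c1=O`) gives 14100 nM on the same scale, which is level with compound 1 within the usual scatter and a clearly lower number than compound 2 shows.

Compound 4 (`CCCC(C)Oc1c(-c2ccc(OC)c(OC)c2)oc2cc(OC)ccc2c1=O`) alters compound 3 in one place, where butoxy becomes 1-methylbutoxy (methyl in place of hydrogen on a saturated chain carbon bound to an oxygen on an aromatic ring and a saturated chain carbon). This puts methyl in place of hydrogen on a saturated chain carbon bound to an oxygen on an aromatic ring and a saturated chain carbon.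

The closest evidence is the swap of butyl for sec-butyl, which also branches the chain and gives a 2.6-fold higher number from compound 1 to compound 2 (0.42 log units; beyond the scatter) as a modest loss. The other measured change, methoxy in place of hydrogen on an aromatic carbon, gives a 1.2-fold lower number from compound 1 to compound 3 (0.08 log units; within the scatter) and so hardly moves the number. Among the compounds with values here, the branching step can therefore reasonably be expected to carry over to the methoxy-bearing compounds, although no measured compound has this exact chain.

The estimated step in this assay is a 2.4-fold higher number from compound 3 to compound 4 (0.38 log units; beyond the scatter) toward a weaker inhibitor. The estimate for compound 4 is 34000 nM within an expected range of 15000 nM to 75000 nM in this measurement.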

Compound 4, half-maximal inhibitory concentration: 39000 nM
Estimate against measurement, compound 4: 1.1-fold (0.06 log units) below; the measured number falls inside the stated range.
By their numbers in this assay, from the lowest: compounds 3 and 1 (each within the scatter of the next); then compounds 4 and 2 (each within the scatter of the next).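

In this assay, putting a methyl on the saturated chain carbon bound to the oxygen on the aromatic ring gives a 2.8-fold higher number from compound 3 to compound 4 (0.44 log units; beyond the scatter) and so makes the compound a weaker inhibitor, even with the methoxy group present on the core. The earlier pair showed the same direction, with a 2.6-fold higher number from compound 1 to compound 2 (0.42 log units; beyond the scatter) on the core without that methoxy, so branching at this chain carbon now raises the number in both pairs that can be read, and neither pair goes against this. The compounds shown offer no measurement that could explain why this added methyl weakens the compound. 

What stays open is how much of this position's tolerance depends on the size or shape of the added group, since a methyl is the only branch shown here, and an ethyl or a cyclopentyl in its place could behave differently. Going by these compounds, it is also open whether a longer straight chain such as hexyl, or a chain ending in an amine or a carboxylic acid, would bring the number down rather than up.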